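Chlorine for Methyl on the Carbonyl Aryl of Compound 3

This account rests on a few compounds, and the source may have more. Where it says the series, first, only, none or still open, it means among the compounds named here.

Compound 1, `O=C(Nc1ccc(Br)cc1CN1C(=O)c2ccccc2C1=O)c1ccccn1`, gives 740 nM in an assay on CHO cells with metabotropic glutamate receptor 5 (Homo sapiens) as the target; on this read-out higher numbers stand for an effect only at larger amounts of compound and lower numbers for an effect already at smaller amounts. Compound 2, `O=C(Nc1cc(-c2ccccc2)nn1-c1ccccc1)c1ccc(F)cc1`, gives 30 nM. Compound 3, `Cc1ccc(C(=O)Nc2cc(-c3ccccc3)nn2-c2ccccc2)cc1`, gives 30 nM.

Compound 3 thus stands level with compound 2 at the digits shown, and together they give the lowest numbers of the three; compound 1, built on a different core, gives a far higher number, well beyond the scatter. Compound 4, `O=C(Nc1cc(-c2ccccc2)nn1-c1ccccc1)c1cccc(Cl)c1`, is compound 3 with a single exchange: 3-chlorophenyl in place of 4-methylphenyl on a carbonyl carbon. Within the data shown here, the one measured step that bears on this place is no change at the digits printed from compound 2 to compound 3 (within the scatter), an exchange on the same aryl ring that moved nothing beyond the scatter. Among the measured compounds shown here, no measured step tells how a chlorine, or a shift of the substituent to another carbon of that ring, acts here, so the data give no ground for expecting movement in either direction. Compound 4 is therefore expected to sit close to compound 3, with an estimated step of no change at the digits printed from compound 3 to compound 4 (within the scatter) in this assay. The estimated value of compound 4 in this assay is 30 nM, with a range from 12 nM to 75 nM.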

Compound 4, half-maximal effective concentration: 40 nM
The estimate for compound 4 lay 1.3-fold (0.12 log units) below the measured number; low and high end bracket the measured number.
By their numbers in this assay, from the lowest: compounds 2, 3 and 4 (each within the scatter of the next); then compound 1.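

In this assay the exchange of 4-methylphenyl for 3-chlorophenyl on the carbonyl carbon gives a 1.3-fold higher number from compound 3 to compound 4 (0.12 log units; within the scatter), and the exchange of 4-fluorophenyl for 3-chlorophenyl gives a 1.3-fold higher number from compound 2 to compound 4 (0.12 log units; within the scatter). Among these compounds, the earlier step covered only two groups, both carried as 4-substituted phenyl; these steps add a chlorine and a substituent on another carbon of the ring, and the number still stays within the scatter of the values for compound 2 and compound 3. At this place, then, the three aryl groups shown cannot be told apart on this read-out, although the data offer no account of why that is so.

From the compounds shown here alone, since compound 4 differs from compound 2 and compound 3 in both the substituent and its ring carbon, the separate contribution of each remains open, and 4-chlorophenyl or 3-methylphenyl would be needed to separate them. Also open, going by these compounds, is whether this tolerance extends to quite different groups on the ring, such as an amine, a carboxylic acid or a longer alkyl chain, or to an unsubstituted phenyl.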